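Notes on the ring-amine substituent: compound 3 to compound 4

The compounds below may be only part of what the source reports. "The series", "measured", "known", "first", "only" and "open" are said of these compounds alone.

Compound 3 `C(#Cc1nc2c(s1)CN(C1CCCCC1)CC2)c1ccccc1` is measured in an assay on HEK293 cells for positive allosteric modulation of metabotropic glutamate receptor 5 (Homo sapiens), read by FLIPR, with a stated time of 1 h (on this read-out lower numbers stand for an effect already at smaller amounts and higher numbers for an effect only at larger amounts of compound), and gives only a limit, > 10000 nM. Compound 1 `Cc1cccc(C#Cc2nc3c(s2)C(=O)NCC3)c1` likewise gives only a limit in this assay, > 10000 nM. Compound 2 `CCCCN1CCc2nc(C#Cc3ccccc3)sc2C1` gives 110 nM in this assay.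

Among the measured compounds shown here, the only measured step that touches the amine nitrogen in the ring is an at least 90-fold higher number from compound 2 to compound 3 (1.95 log units; beyond the scatter); its true size is open-ended because of the limit of > 10000 nM in this assay, at which 2 of the 3 values shown sit. Compound 4 `CC1CC(C(=O)N2CCc3nc(C#Cc4ccccc4)sc3C2)C1` differs from compound 3 by (3-methylcyclobutyl)carbonyl in place of cyclohexyl on an amine nitrogen in a ring. For the measured compounds named here, no measured pair exchanges a cyclohexyl for a carbonyl-bearing group on this nitrogen, so the measured steps give no direct guide; they show only that the butyl of compound 2 sits well within the measured range while the cyclohexyl of compound 3 falls outside it. A return toward the range of compound 2 is therefore possible but uncertain, and the estimate is wide. Compound 4 is expected to give about 2000 nM, within 200 nM to 10000 nM. This corresponds to an expected step of an at least 5.0-fold lower number from compound 3 to compound 4 (0.69 log units; beyond the scatter).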

Compound 4, half-maximal effective concentration: 81 nM
For compound 4 the middle estimate is 25-fold (1.39 log units) above the measured one; measured number below the stated range.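

With (3-methylcyclobutyl)carbonyl on the amine nitrogen in a ring, the series shows an at least 120-fold lower number from compound 3 to compound 4 (2.09 log units; beyond the scatter), so a group carrying a carbonyl and a carbon ring can stand on this nitrogen with a measurable effect, which the result for cyclohexyl did not suggest. Against butyl, the same group gives a 1.4-fold lower number from compound 2 to compound 4 (0.13 log units; within the scatter), which is within the scatter, so the two substituents cannot be told apart in this assay. The true size of the step from cyclohexyl remains open-ended: the limit of > 10000 nM in this assay, at which 2 of the 4 values shown sit.

The change swaps the six-membered ring for a four-membered one and adds the carbonyl in one move, and the compounds shown do not separate these two differences. A cyclohexylcarbonyl or a plain 3-methylcyclobutyl on this nitrogen would bear directly on that question.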